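A few compounds are considered here, and "the series" means these few. Any claim that something is new, unique, unknown or untested is made for them only; others in the source may bear on it.

Measured compounds:
compound 1, `CCCn1c(=O)[nH]c2nc(-c3ccc(S(=O)(=O)N4CCN(Cc5cccc(Br)c5)CC4)cc3)[nH]c2c1=O`, giving 0.148 nM in an assay on CHO cells for displacement of a labelled ligand from adenosine receptor A2b (Homo sapiens), read by scintillation counting, with a stated time of 75 min, in the presence of a further agent that is not named here; a lower number here means a stronger inhibitor, a higher number a weaker inhibitor
compound 2, `CCCn1c(=O)c2[nH]c(-c3ccc(S(=O)(=O)N4CCN(c5ccc(Cl)cc5)CC4)cc3)nc2n(C)c1=O`, giving 1.91 nM in this assay

Compound 1 stands lowest of the two numbers in this assay. Its nearest neighbour is compound 2, whose number is higher by a margin beyond the usual scatter. The two compounds differ in more than one place at once, so the account says nothing about what carries that gap.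

Compound 3, `CCCn1c(=O)[nH]c2nc(-c3ccc(S(=O)(=O)N4CCN(Cc5ccc(Br)c(F)c5)CC4)cc3)[nH]c2c1=O`, is the compound still to be measured. It differs from compound 1 in a single place: 4-bromo-3-fluorophenyl in place of 3-bromophenyl on a saturated chain carbon bound to an amine nitrogen in a ring. For the measured compounds named here, no pair of measured compounds shows a step of this kind, so there is no measured step to lean on. Since the change adds a single fluorine to a halogenated ring on the same benzyl arm and keeps the rest of compound 1 untouched, the expected step in this assay is small, with no clear direction and within the scatter. The estimate for compound 3 in this assay is therefore 0.2 nM, with a range from 0.07 nM to 0.6 nM, meaning an expected step of a 1.4-fold higher number from compound 1 to compound 3 (0.13 log units; within the scatter).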

Compound 3, inhibition constant: 0.473 nM
Beside the measured number, compound 3's estimate is 2.4-fold (0.37 log units) below it; low and high end bracket the measured number.
By their numbers in this assay, from the lowest: compound 1; then compound 3; then compound 2.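

In this assay, for the compounds shown here, the change from 3-bromobenzyl to 4-bromo-3-fluorobenzyl gives the first step that can be read at a single place in these compounds: a 3.2-fold higher number from compound 1 to compound 3 (0.50 log units; beyond the scatter). The number therefore responds to the substitution on the aromatic ring of this benzyl arm, and the added fluorine with the altered bromine pattern costs a modest amount rather than leaving the number unchanged, with compound 3 still at 0.473 nM. No measurement shown here accounts for the size or direction of this step.

Going by these compounds alone, the two names differ in both the placement of the bromine and the presence of the fluorine, so this single step cannot show how much each contributes, and it describes only this one pair of ring patterns. Going by these compounds, how the number would respond to an unsubstituted benzyl group, or to a methoxy group, an amine or a carboxylic acid on the same ring, remains open, as does whether this step would carry over to the core of compound 2.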